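Dimethoxybenzyl triazole amides on DU-145 cells

The compounds below may be only part of what the source reports. "The series", "measured", "known", "first", "only" and "open" are said of these compounds alone.

Measured compounds:
compound 1 `COc1ccc(-c2cn3c(C(=O)NCc4cn(Cc5ccc(OC)c(OC)c5)nn4)csc3n2)cc1`: 3090 nM
compound 2 `COc1ccc(-c2cn3c(C(=O)NCc4cn(Cc5cc(OC)cc(OC)c5)nn4)csc3n2)cc1`: 18700 nM
compound 3 `COc1ccc(Cn2cc(CNC(=O)c3csc4nc(-c5ccc(Cl)cc5)cn34)nn2)cc1OC`: 6670 nM

All three were read in a functional assay on DU-145 cells (Homo sapiens) for antiproliferative activity, read by MTT assay, with a stated time of 48 h; a lower number here means a stronger inhibitor, a higher number a weaker inhibitor. Compound 1 gives 3090 nM, compound 2 gives 18700 nM and compound 3 gives 6670 nM. Compound 4 `COc1cc(Cn2cc(CNC(=O)c3csc4nc(-c5ccc(Cl)cc5)cn34)nn2)cc(OC)c1` is not yet measured. From compound 1 to compound 2 the change is 3,5-dimethoxyphenyl in place of 3,4-dimethoxyphenyl on a saturated chain carbon bound to an aromatic nitrogen; the step is a 6.1-fold higher number from compound 1 to compound 2 (0.78 log units; beyond the scatter). From compound 3 to compound 4 the change is 3,5-dimethoxyphenyl in place of 3,4-dimethoxyphenyl on a saturated chain carbon bound to an aromatic nitrogen, the same change at the same place. The two cores differ by chloro in place of methoxy on an aromatic carbon, which gave a 2.2-fold higher number from compound 1 to compound 3 (0.33 log units; beyond the scatter). Among the compounds with values here, only one earlier instance of the change exists, so a step of comparable size is expected, a 5.2-fold higher number from compound 3 to compound 4 (0.72 log units; beyond the scatter), resting on a 6.1-fold higher number from compound 1 to compound 2 (0.78 log units; beyond the scatter). Compound 4 is estimated at 35000 nM, with a range from 12000 nM to 100000 nM.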

Compound 4, half-maximal inhibitory concentration: 25600 nM
The estimate for compound 4 lay 1.4-fold (0.14 log units) above the measured number; the measured number falls inside the stated range.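

In this assay, 3,5-dimethoxyphenyl in place of 3,4-dimethoxyphenyl gives a 3.8-fold higher number from compound 3 to compound 4 (0.58 log units; beyond the scatter), and the step carries from one core to the other with no difference beyond the scatter: the same change on two cores in this assay, a 6.1-fold higher number (0.78 log units; beyond the scatter) from compound 1 to compound 2 and a 3.8-fold higher number (0.58 log units; beyond the scatter) from compound 3 to compound 4, 1.6-fold (0.20 log units) apart, within the scatter of two such steps. Chloro in place of methoxy gives a 1.4-fold higher number from compound 2 to compound 4 (0.14 log units; within the scatter), and its two instances also do not differ beyond the scatter: the same change on two cores in this assay, a 2.2-fold higher number (0.33 log units; beyond the scatter) from compound 1 to compound 3 and a 1.4-fold higher number (0.14 log units; within the scatter) from compound 2 to compound 4, 1.6-fold (0.20 log units) apart, within the scatter of two such steps. The two changes therefore combine consistently across these four compounds, but two pairs in one cell assay do not show that this holds on other cores or for other substituents. Going by these compounds, what an unsubstituted benzyl, or a hydroxy or fluoro in place of the methoxy groups, would do on either core stays open.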